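This account rests on a few compounds, and the source may have more. Where it says the series, first, only, none or still open, it means among the compounds named here.

Compound 1 `CC(=O)Nc1ccc(NC(=O)NCCCCC(c2ccc(F)cc2)c2ccc(F)cc2)cc1` is reported in a functional assay on MDA-MB-231 cells (Homo sapiens) for cytotoxicity, read by MTT assay, with a stated time of 48 h (a higher number here means a weaker inhibitor, a lower number a stronger inhibitor), only as a limit of the assay, > 20000 nM. Compound 2 `O=C(NCCCCC(c1ccc(F)cc1)c1ccc(F)cc1)Nc1cccc(C(F)(F)F)c1` gives 3380 nM. Compound 3 `O=C(NCCCCC(c1ccc(F)cc1)c1ccc(F)cc1)Nc1cccc(Cl)c1` gives 5070 nM.

Compound 2 holds the lower of the two numbers in this assay, with compound 3 nearest, a step of a 1.5-fold higher number from compound 2 to compound 3 (0.18 log units; within the scatter); the remaining value is a limit (the limit of > 20000 nM in this assay, at which 1 of the 3 values shown sits). Compound 4 `O=C(NCCCCC(c1ccc(F)cc1)c1ccc(F)cc1)Nc1ccc(Cl)cc1C(F)(F)F` differs from compound 2 by 4-chloro-2-(trifluoromethyl)phenyl in place of 3-(trifluoromethyl)phenyl on an amide-type nitrogen. For the measured compounds named here, three measured steps bear on this change: an at least 5.9-fold lower number from compound 1 to compound 2 (0.77 log units; beyond the scatter), an at least 3.9-fold lower number from compound 1 to compound 3 (0.59 log units; beyond the scatter) and a 1.5-fold higher number from compound 2 to compound 3 (0.18 log units; within the scatter). Replacing the 4-acetamidophenyl moved the number well beyond the scatter, whereas exchanging trifluoromethyl for chloro stayed within it. Compound 4 keeps a trifluoromethyl and adds a chloro, so in this assay a step of about a 1.1-fold lower number from compound 2 to compound 4 (0.05 log units; within the scatter) is expected. Compound 4 is estimated at 3000 nM, with a range from 1200 nM to 8000 nM.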

Compound 4, half-maximal inhibitory concentration: > 20000 nM
Compound 4 gave a limit, no number (the forecaster's own chance of this, stated with the estimate: 5%); at least 6.6-fold (0.82 log units) between middle value and limit.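

On the amide-type nitrogen, the aryl group's substitution matters more than the earlier chloro-for-trifluoromethyl exchange suggested. In this assay, 4-chloro-2-(trifluoromethyl)phenyl gives an at least 5.9-fold higher number from compound 2 to compound 4 (0.77 log units; beyond the scatter) and an at least 3.9-fold higher number from compound 3 to compound 4 (0.59 log units; beyond the scatter), so keeping a trifluoromethyl and adding a chloro does not preserve the activity of the two simpler aryl groups. Compound 4 gives only a limit, as does compound 1, so the step between them cannot be read: the limit of > 20000 nM in this assay, at which 2 of the 4 values shown sit.

Still open, on these data alone, is whether a 4-chlorophenyl or a 2-(trifluoromethyl)phenyl on the same nitrogen would behave like compound 2 or like compound 4.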